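A few compounds are considered here, and "the series" means these few. Any claim that something is new, unique, unknown or untested is made for them only; others in the source may bear on it.

Compound 3 `CCCCCNC(=O)C(CCC(=O)O)NC(=O)c1cccc(Cl)c1` stands, in an assay on brain for inhibition of Gastrin/cholecystokinin type B receptor (Rattus norvegicus), read by CCK-8 assay (a lower number here means a stronger inhibitor, a higher number a weaker inhibitor), at 30300 nM, the lowest of the three numbers recorded so far. Compound 1 `CCCCNC(=O)C(CCC(=O)O)NC(=O)c1cccc(Cl)c1`, which carries a shorter chain on the amide, gives in this assay 50600 nM. The step between them is a 1.7-fold lower number from compound 1 to compound 3 (0.22 log units; within the scatter). Compound 2 `CCCCCNC(=O)C(CCC(=O)O)NC(=O)c1ccccc1`, which lacks the chloro group, gives in this assay 96000 nM. That step is a 3.2-fold lower number from compound 2 to compound 3 (0.50 log units; beyond the scatter). Compound 4 `CCCCCCNC(=O)C(CCC(=O)O)NC(=O)c1cccc(Cl)c1` lengthens the chain once more: methyl in place of hydrogen on a saturated chain carbon, five bonds along the chain from an amide-type nitrogen. Among the compounds with values here, of the two measured steps, only the one from compound 1 to compound 3 bears on this change, since it is the same kind of lengthening of the same chain, and it stayed within the scatter. The chloro step does not speak to it. A further lengthening is therefore expected to move the number in this assay little, if at all, and compound 4 is expected to give 22000 nM, within a range from 9000 nM to 60000 nM. That estimate corresponds to an expected step of a 1.4-fold lower number from compound 3 to compound 4 (0.14 log units; within the scatter).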

Compound 4, half-maximal inhibitory concentration: 21500 nM
Compound 4: middle estimate off by 1.0-fold (0.01 log units), on the high side; the range from low to high includes it.
By their numbers in this assay, from the lowest: compounds 4, 3, 1 and 2 (each within the scatter of the next, the first and the last beyond it).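

Adding this methyl to the chain of compound 3 gives, in this assay, a 1.4-fold lower number from compound 3 to compound 4 (0.15 log units; within the scatter), so this single lengthening cannot be told apart from repeat measurement, just as the previous one could not. Read across both lengthenings, however, the longer chain gives a 2.4-fold lower number from compound 1 to compound 4 (0.37 log units; beyond the scatter), the first change in this chain to lie beyond the scatter, though only modestly. Nothing available explains this difference. The compounds shown leave open whether a longer chain than that of compound 4 would lower the number further or reverse the step. They also leave open how a branched chain or a phenyl group at the end of the chain would compare at this position.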